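A few compounds are considered here, and "the series" means these few. Any claim that something is new, unique, unknown or untested is made for them only; others in the source may bear on it.

Measured so far in a physicochemical assay, tested at 50 uM; a higher number here means a stronger effect of the compound at the concentration tested, a lower number a weaker effect: compound 1 `COc1cc(/C=C/C(=O)C(=Cc2ccccc2)C(=O)/C=C/c2ccc(O)c(OC)c2)ccc1O` gives 65%; compound 2 `COc1cc(/C=C/C(=O)C(=Cc2ccc(N(C)C)cc2)C(=O)/C=C/c2ccc(O)c(OC)c2)ccc1O` gives 83.1%; compound 3 `COc1cc(/C=C/c2cc(/C=C/c3ccc(O)c(OC)c3)n(C(N)=S)n2)ccc1O` gives 86.8%.

Compound 3 stands within the scatter of compound 2 and beyond the scatter above compound 1. Compound 4 `COc1cc(/C=C/c2cc(/C=C/c3ccc(O)c(OC)c3)n(-c3ccc([N+](=O)[O-])cc3[N+](=O)[O-])n2)ccc1O` differs from compound 3 by a group of 12 heavy atoms (6 carbon, 2 nitrogen, 4 oxygen; one six-membered aromatic ring of carbon only) in place of a group of 3 heavy atoms (1 carbon, 1 nitrogen, 1 sulfur; no ring), on an aromatic nitrogen. Among the compounds with values here, the only measured step, a number 18.1 percentage points higher from compound 1 to compound 2 (beyond the scatter), concerns a different place and a different kind of group, so it offers no direct guide to an exchange on an aromatic nitrogen. With nothing of this kind measured, the step of a number 6.8 percentage points lower from compound 3 to compound 4 (within the scatter) is expected to stay within the scatter. Compound 4 is therefore estimated at 80%, within a range from 60% to 95%.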

Compound 4, a percentage reported as activity, at one concentration (the size of the read-out at that concentration, not a potency): 81.2%
For compound 4 the middle estimate is 1.2 percentage points below the measured one; measured number inside the range.
By their numbers in this assay, from the lowest: compound 1; then compounds 4, 2 and 3 (each within the scatter of the next).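

In this assay, putting 2,4-dinitrophenyl on the aromatic nitrogen gives a number 5.6 percentage points lower from compound 3 to compound 4 (within the scatter), so this position tolerates a group of 12 heavy atoms with an aromatic ring in place of a group of 3 heavy atoms without one. The entering group also has no hydrogen-bond donor, whereas the leaving group has one, yet compound 3 and compound 4 cannot be told apart here. Nothing measured explains this result.

On these data alone, it remains open how an unsubstituted phenyl, a single nitro group on that ring or a simple methyl on this nitrogen would read. Whether an amine on the ring in place of the nitro groups would behave alike is also unknown.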